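Benzamide-substituted core series: phenethyl to butyl step

The compounds below may be only part of what the source reports. "The series", "measured", "known", "first", "only" and "open" are said of these compounds alone.

Three compounds of the shared core are measured in a functional assay on HT-29 cells (Homo sapiens) for inhibition, read by MTT assay, with a stated time of 2 days; on this read-out higher numbers stand for weaker inhibition of growth and lower numbers for stronger inhibition of growth. Compound 1 `COc1cccc(-c2nc3c(-c4ccc(Cl)cc4)n[nH]c3c(=O)n2NC(=O)c2ccccc2)c1` gives 20400 nM in this assay. Compound 2 `COc1cccc(Cc2nc3c(-c4ccc(Cl)cc4)n[nH]c3c(=O)n2NC(=O)c2ccccc2)c1` gives 22100 nM, and compound 3 `O=C(Nn1c(CCc2ccccc2)nc2c(-c3ccc(Cl)cc3)n[nH]c2c1=O)c1ccccc1` gives 23400 nM. The three numbers lie within the scatter of one another: a 1.1-fold higher number from compound 1 to compound 3 (0.06 log units; within the scatter) and a 1.1-fold higher number from compound 2 to compound 3 (0.02 log units; within the scatter), so compound 3 cannot be set apart from compound 1 or compound 2 on these numbers.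

Compound 4 `CCCCc1nc2c(-c3ccc(Cl)cc3)n[nH]c2c(=O)n1NC(=O)c1ccccc1` differs from compound 3 by ethyl in place of phenyl on a saturated chain carbon, two bonds along the chain from an aromatic carbon. The variations measured so far all sit at this same position of the core, and each was flat: a 1.1-fold higher number from compound 1 to compound 2 (0.03 log units; within the scatter), a 1.1-fold higher number from compound 2 to compound 3 (0.02 log units; within the scatter), and a 1.1-fold higher number from compound 1 to compound 3 (0.06 log units; within the scatter). Within the data shown here, no measured step shows the effect of removing the aromatic ring from this chain altogether, so the expectation rests on the flatness seen across compound 1, compound 2 and compound 3. In this assay the step from compound 3 to compound 4 is expected to be a 1.0-fold higher number from compound 3 to compound 4 (0.01 log units; within the scatter). Compound 4 is therefore estimated at 24000 nM, with a range from 10000 nM to 55000 nM.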

Compound 4, concentration for 50% growth inhibition: 710 nM
The estimate for compound 4 lay 34-fold (1.53 log units) above the measured number; the measured number lies below the stated range.
By their numbers in this assay, from the lowest: compound 4; then compounds 1, 2 and 3 (each within the scatter of the next).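

In this assay this position proves sensitive to the change: butyl on the aromatic carbon of the shared core stands apart from all three ring-bearing substituents (a 33-fold lower number from compound 3 to compound 4 (1.52 log units; beyond the scatter); a 31-fold lower number from compound 2 to compound 4 (1.49 log units; beyond the scatter); a 29-fold lower number from compound 1 to compound 4 (1.46 log units; beyond the scatter)). Compounds 1, 2 and 3 remain within the scatter of one another with the aromatic ring attached directly, through one carbon or through two, so among these four compounds the large steps appear only with the ring-free chain. Nothing at hand accounts for the size of these steps.

As far as these compounds go, whether the gain is specific to butyl remains open, since a shorter propyl chain or a longer hexyl chain could give a different number. Also open, from the compounds shown here alone, is how a saturated cyclohexyl ring, or an amine or carboxylic acid at the end of the chain, would read.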